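Swapping bromo for cyano on the benzyl ring

This account rests on a few compounds, and the source may have more. Where it says the series, first, only, none or still open, it means among the compounds named here.

Measured so far:
compound 1, `CC(C)(C)c1cc(/C=C/C(=O)NCCC2CCN(Cc3cccc(F)c3)CC2)cc(C(C)(C)C)c1O`: 6500 nM
compound 2, `CC(C)(C)c1cc(/C=C/C(=O)NCCC2CCN(Cc3ccc(Br)cc3)CC2)cc(C(C)(C)C)c1O`: 13200 nM

Both compounds share one core and differ only in the group carried on the ring attached to the amine nitrogen. In an assay on isolated protein for inhibition of Amine oxidase [flavin-containing] B (Homo sapiens), read by fluorescence, with stated times of 15 min and 20 min (a higher number here means a weaker inhibitor, a lower number a stronger inhibitor), compound 1 gives 6500 nM, while compound 2 gives 13200 nM, the higher of the two numbers; the step of a 2.0-fold higher number from compound 1 to compound 2 (0.31 log units; beyond the scatter) is modest, though beyond the scatter. Compound 3, `CC(C)(C)c1cc(/C=C/C(=O)NCCC2CCN(Cc3ccc(C#N)cc3)CC2)cc(C(C)(C)C)c1O`, has not yet been measured. It differs from compound 2 in one place: cyano in place of bromo on an aromatic carbon. Going by the values given here, the single measured step, a 2.0-fold higher number from compound 1 to compound 2 (0.31 log units; beyond the scatter), exchanges one halogen-bearing ring for another, so it does not bear directly on replacing bromo with cyano; no measured pair shows that exchange. With nothing pointing in either direction, compound 3 is expected to sit close to compound 2, with a step of a 1.1-fold lower number from compound 2 to compound 3 (0.04 log units; within the scatter) that stays within the scatter. Compound 3 is therefore estimated at 12000 nM, with a range from 5000 nM to 30000 nM.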

Compound 3, half-maximal inhibitory concentration: 13900 nM
Beside the measured number, compound 3's estimate is 1.2-fold (0.06 log units) below it, within the range that was stated.
By their numbers in this assay, from the lowest: compound 1; then compounds 2 and 3 (each within the scatter of the next).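

In this assay, the step of a 1.1-fold higher number from compound 2 to compound 3 (0.02 log units; within the scatter) shows that at this aromatic carbon, para to a large group, bromo and cyano cannot be told apart, even though cyano brings a triple bond and a hydrogen-bond acceptor that bromo lacks. The earlier compounds shown here offered only a change from 3-fluorophenyl to 4-bromophenyl, and the new step of a 2.1-fold higher number from compound 1 to compound 3 (0.33 log units; beyond the scatter) is a modest one that shows a second 4-substituted ring also reading above compound 1, as the earlier step of a 2.0-fold higher number from compound 1 to compound 2 (0.31 log units; beyond the scatter) did for bromo. No measurement shown here explains why bromo and cyano read alike.

Still open, as far as these compounds go, is whether the gap from compound 1 comes from where the ring's group sits or from which group it is, since both steps from compound 1 change the two together, and a 4-fluorophenyl compound would separate them. From the compounds shown here alone, it is also open how far this tolerance extends, for instance whether an amine, a carboxylic acid or a methoxy group on the same carbon would read like bromo and cyano or would shift the number beyond the scatter.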